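Two inactive amides and a chloropyridyl variant

The source may hold more compounds than are shown below. What is called first, only, known or untested is meant among the compounds shown, and "the series" means these compounds.

Compound 1 `O=C(Nc1ccc(Cl)c(-c2nnc3c(Cl)cccn23)c1)c1ccc(F)cc1Cl` carries a 2-chloro-4-fluorophenyl group on the carbonyl carbon of its amide. In a functional assay on AN3-CA cells (Homo sapiens) for antiproliferative activity, read by MTT assay, with a stated time of 72 h (on this read-out lower numbers stand for stronger inhibition and higher numbers for weaker inhibition), compound 1 gives > 100000 nM, which is a limit of the assay rather than a number. Compound 2 `O=C(Nc1ccc(Cl)c(-c2nnc3c(Cl)cccn23)c1)c1cccnc1` replaces that group with pyridin-3-yl. In this assay compound 2 also gives > 100000 nM, again a limit. The step that the two limits leave unreadable from compound 1 to compound 2 is therefore of unknown size, since the limit of > 100000 nM in this assay, at which 2 of the 2 values shown sit, holds both values. Compound 3 `O=C(Nc1ccc(Cl)c(-c2nnc3c(Cl)cccn23)c1)c1cccnc1Cl` is the variant not yet measured; it differs from compound 1 by 2-chloropyridin-3-yl in place of 2-chloro-4-fluorophenyl on a carbonyl carbon. Within the data shown here, no measured step bears readably on this change, and the only evidence is that both neighbours sit at the limit. Compound 3 is therefore expected to remain at or near that limit, with an estimated step that the limit leaves unreadable from compound 1 to compound 3. The estimate for compound 3 is 150000 nM, within a range from 40000 nM to 500000 nM.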

Compound 3, half-maximal inhibitory concentration: > 100000 nM
Compound 3 gave a limit, no number (the forecaster's own chance of this, stated with the estimate: 80%); the middle value lies beyond the limit too.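

No new step can be read among compound 1, compound 2 and compound 3, because all three stand at one limit in this assay: the limit of > 100000 nM in this assay, at which 3 of the 3 values shown sit.

The compounds shown leave open how these three compare with one another, and which group on the carbonyl carbon, if any, would give a measurable value.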